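From 4-aminophenyl to 1-phenylethyl on a shared core

This account rests on a few compounds, and the source may have more. Where it says the series, first, only, none or still open, it means among the compounds named here.

Values measured in a functional assay on HCT-116 cells (Homo sapiens) for cytotoxicity, read by MTT assay, with a stated time of 72 h (a higher number here means a weaker inhibitor, a lower number a stronger inhibitor), are these.
Compound 1 (`CC(C)(C)OC(=O)N1CCN(c2c(C(=O)NCc3ccc(F)cc3)nc(Br)c3cccnc23)CC1`): > 10000 nM (a limit of the assay, not a number)
Compound 2 (`Nc1ccc(Nc2c(C(=O)NCc3ccc(F)cc3)nc(Br)c3cccnc23)cc1`): 7000 nM

Among the measured compounds shown here, only two compounds have been tested so far, and no step between them can be read. Compound 1 is recorded only at the limit of > 10000 nM in this assay, at which 1 of the 2 values shown sits, which is a limit. For the measured compounds named here, compound 2, at 7000 nM, holds the only actual number in the set, so it has no measured neighbour to be ranked against.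

The next compound is compound 3 (`C[C@H](Nc1c(C(=O)NCc2ccc(F)cc2)nc(Br)c2cccnc12)c1ccccc1`), which keeps the shared core and changes one group: 1-phenylethyl in place of 4-aminophenyl on a nitrogen on an aromatic ring. In words, 1-phenylethyl stands in place of 4-aminophenyl on a nitrogen on an aromatic ring, and the new group brings a defined stereocentre.

Going by the values given here, no measured pair shows what a swap of this kind does in this assay, so the expectation is no change beyond the usual scatter, starting from compound 2 at 7000 nM. The estimated change is a 1.1-fold higher number from compound 2 to compound 3 (0.06 log units; within the scatter), which is expected to stay small. For compound 3 the expected value is 8000 nM, with an estimated range from 3000 nM to 20000 nM.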

Compound 3, half-maximal inhibitory concentration: > 20000 nM
Compound 3: a limit, no number; the forecaster's own chance of this, stated with the estimate: 35%; middle value at least 2.5-fold (0.39 log units) away from the limit.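

Among the compounds shown here, the first step that can be read at this position in this assay is an at least 2.8-fold higher number from compound 2 to compound 3 (0.45 log units; beyond the scatter), so on this shared core the move from (4-aminophenyl)amino to (1-phenylethyl)amino does not preserve even the modest cytotoxicity of compound 2. Compound 3 gives no number, only a limit of the assay: the limit of > 20000 nM in this assay, at which 1 of the 3 values shown sits. The change also shows that a six-membered aromatic ring of carbon in the entering group is not enough to hold the activity of compound 2, although the step alone cannot separate the loss of the amine, with its hydrogen-bond donor and acceptor, from the added stereocentre and the extra carbon, since all of these change together.

On these data alone, how far compound 3 actually lies from compound 2 stays open, as does whether its opposite stereoisomer would behave in the same way. As far as these compounds go, it is also open whether a plain benzyl group, or a 4-hydroxyphenyl group in place of 4-aminophenyl on that nitrogen, would give a measurable number in this assay.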